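Swapping the Aryl Ether Substituent on a Shared Core

The source may report more compounds than this note shows. Statements on the series, on what has been measured and on what is new or still open speak of the compounds shown alone.

Compound 3 `CC(=O)Nc1cccc(Oc2nc(NCC3CCOCC3)n3ncc(-c4ccc(C(=O)NC5CC5)c(C)c4)c3n2)c1` has been measured in a functional assay on OVCAR-3 cells (Homo sapiens) for antiproliferative activity (on this read-out lower numbers stand for stronger inhibition of growth and higher numbers for weaker inhibition of growth), where compound 3 gives 1200 nM. Among the three compounds measured it holds the second highest number. Its nearest neighbour is compound 2 `Cc1cc(-c2cnn3c(NCC4CCOCC4)nc(Nc4ccccc4)nc23)ccc1C(=O)NC1CC1`, which in this assay gives 1700 nM; the furthest is compound 1 `Cc1cc(-c2cnn3c(NCC4CCOCC4)nc(NC4CCOCC4)nc23)ccc1C(=O)NC1CC1`, which in this assay gives 780 nM. Both gaps stay within the scatter: a 1.4-fold lower number from compound 2 to compound 3 (0.15 log units; within the scatter) and a 1.5-fold higher number from compound 1 to compound 3 (0.19 log units; within the scatter). For the measured compounds named here, the only step beyond the scatter in this small set is a 2.2-fold higher number from compound 1 to compound 2 (0.34 log units; beyond the scatter).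

Compound 4 `Cc1cc(-c2cnn3c(NCC4CCOCC4)nc(Oc4cccc(F)c4F)nc23)ccc1C(=O)NC1CC1` differs from compound 3 in one place: 2,3-difluorophenyl in place of 3-acetamidophenyl on an oxygen on an aromatic ring. Going by the values given here, no measured step alters the group on that oxygen; the two steps that touch this part of the core exchange whole substituents on the aromatic carbon, and both stayed within the scatter. Among the compounds with values here, the one step beyond the scatter concerned a different exchange. For compound 4 the expected step is therefore a 1.3-fold higher number from compound 3 to compound 4 (0.10 log units; within the scatter), within the scatter, with no firm direction. The estimate for compound 4 in this assay is 1500 nM, with a range from 500 nM to 4500 nM.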

Compound 4, concentration for 50% growth inhibition: 37 nM
The estimate for compound 4 lay 41-fold (1.61 log units) above the measured number; measured number outside the range, below it.
By their numbers in this assay, from the lowest: compound 4; then compounds 1, 3 and 2 (each within the scatter of the next, the first and the last beyond it).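

In this assay, the group on the oxygen proves far more decisive than the earlier exchanges on this aromatic carbon suggested: 2,3-difluorophenyl in place of 3-acetamidophenyl gives a large step (a 32-fold lower number from compound 3 to compound 4 (1.51 log units; beyond the scatter)). The earlier substituents here, (oxan-4-yl)amino, anilino and 3-acetamidophenoxy, spanned at most a modest step, yet 2,3-difluorophenoxy stands clearly apart from the two amino groups as well (a 46-fold lower number from compound 2 to compound 4 (1.66 log units; beyond the scatter); a 21-fold lower number from compound 1 to compound 4 (1.32 log units; beyond the scatter)). The aryl ether link alone therefore does not set the level, as compound 3 and compound 4 share it and still lie far apart.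

On these data alone, whether a plain phenyl, a single fluoro group, two chloro groups or an amine on that ring would hold this level remains open. Nothing available accounts for the size of this step.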